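This account rests on a few compounds, and the source may have more. Where it says the series, first, only, none or still open, it means among the compounds named here.

Measured compounds:
Compound 1 `CC(C)CCn1c(Cn2c(=O)n(C(C)C)c3ccccc32)nc2c(CN)cccc21`: in an ADME assay on HEp-2 cells (Homo sapiens) for cytotoxicity (a higher number here means that more compound is tolerated, a lower number that less compound is tolerated), compound 1 gives 7000 nM.
Compound 2 `CC(C)CCn1c(Cn2c(=O)n(C(C)C)c3ccccc32)nc2ccc(CN)cc21`: compound 2 gives 28100 nM.
Compound 3 `CC(C)CCn1c(Cn2c(=O)n(C(C)C)c3ccccc32)nc2ccc(CO)cc21`: compound 3 gives 81600 nM.

Compound 1 has the lowest of the three numbers, so the least compound is tolerated. Compound 2 and compound 1 are built from the same atoms joined differently; the difference between the two cores is not broken down here. From compound 2 to compound 3 one change is made, (hydroxy in place of amino on a saturated chain carbon bound to an aromatic carbon), and it gives a 2.9-fold higher number from compound 2 to compound 3 (0.46 log units; beyond the scatter).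

Compound 4 `CC(C)CCn1c(Cn2c(=O)n(C(C)C)c3ccccc32)nc2c(CO)cccc21` is not yet measured. It stands to compound 1 exactly as compound 3 stands to compound 2: the change is hydroxy in place of amino on a saturated chain carbon bound to an aromatic carbon, made at the same kind of place, so it is the same change seen a second time. For the measured compounds named here, with only a single earlier example, the expectation for compound 4 rests on that one step. A step of similar size, a 2.9-fold higher number from compound 1 to compound 4 (0.46 log units; beyond the scatter), is expected because compound 2 to compound 3 gave a 2.9-fold higher number from compound 2 to compound 3 (0.46 log units; beyond the scatter). Compound 4 is therefore estimated at 20000 nM, with a likely range from 8000 nM to 50000 nM.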

Compound 4, half-maximal cytotoxic concentration: 22000 nM
Compound 4: middle estimate off by 1.1-fold (0.04 log units), on the low side; low and high end bracket the measured number.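

Replacing aminomethyl with hydroxymethyl gives a 3.1-fold higher number from compound 1 to compound 4 (0.50 log units; beyond the scatter) in this assay on the core of compound 1, so more compound is tolerated once the amino group is gone. Set beside the earlier example, the change keeps much the same size when it is carried from one core to the other: the same change on two cores in this assay, a 2.9-fold higher number (0.46 log units; beyond the scatter) from compound 2 to compound 3 and a 3.1-fold higher number (0.50 log units; beyond the scatter) from compound 1 to compound 4, 1.1-fold (0.03 log units) apart, within the scatter of two such steps. For the compounds shown here, this rests on only two matched pairs in a single assay, so it shows that the step held on these two cores, but it does not show that it would hold on a further core or in another kind of measurement, and it does not explain why the number moves.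

The compounds shown carry only aminomethyl or hydroxymethyl, so it remains open how a carboxylic acid, a methyl ether or a longer chain ending in an amine would compare. From the compounds shown here alone, it also remains open whether the same swap would give a step of this size at any other place on the shared core.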